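This account rests on a few compounds, and the source may have more. Where it says the series, first, only, none or still open, it means among the compounds named here.

Measured so far:
compound 1 `O=C(NO)c1ccc(/C=C/c2ccnc(-c3cc(F)ccc3O)c2)cc1` gives 2040 nM
compound 2 `O=C(NO)c1ccc(/C=C/c2ccnc(-c3cccnc3)c2)cc1` gives 5140 nM
compound 3 `Cc1ccc(-c2cc(/C=C/c3ccc(C(=O)NO)cc3)c(F)cn2)c(F)c1` gives 1670 nM

In a functional assay on HCT-116 cells (Homo sapiens) for antiproliferative activity, read by CellTiter-Glo, with a stated time of 72 h (a lower number here means a stronger inhibitor, a higher number a weaker inhibitor), compound 1 stands second highest of the three numbers; compound 3 lies within the scatter of it, while compound 2 lies beyond. Compound 4 `O=C(NO)c1ccc(/C=C/c2ccnc(Br)c2)cc1` has not yet been measured. It differs from compound 1 in one place: bromo in place of 5-fluoro-2-hydroxyphenyl on an aromatic carbon. Among the compounds with values here, the only measured step that bears on this change is a 2.5-fold higher number from compound 1 to compound 2 (0.40 log units; beyond the scatter), where one aromatic ring gave way to another and the number rose modestly. Replacing the whole ring with a single bromine is a larger structural change, so a weaker inhibitor is expected, with a step of a 3.2-fold higher number from compound 1 to compound 4 (0.50 log units; beyond the scatter). Compound 4 is therefore estimated at 6500 nM, within a range from 2500 nM to 17000 nM.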

Compound 4, half-maximal inhibitory concentration: > 10000 nM
Compound 4 ended at the assay's limit; the forecaster's own chance of this, stated with the estimate: 10%; at least 1.5-fold (0.18 log units) between middle value and limit.
By their numbers in this assay, from the lowest: compounds 3 and 1 (each within the scatter of the next); then compound 2. At a limit, above all of these: compound 4.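

In this assay compound 4 gives a limit and not a number: the limit of > 10000 nM in this assay, at which 1 of the 4 values shown sits. With a single bromo on the aromatic carbon next to the ring nitrogen and no ring there, the result is an at least 4.9-fold higher number from compound 1 to compound 4 (0.69 log units; beyond the scatter), so this position tolerates losing the 5-fluoro-2-hydroxyphenyl ring less well than swapping it for pyridin-3-yl. Against the pyridin-3-yl compound, the result is an at least 1.9-fold higher number from compound 2 to compound 4 (0.28 log units; that floor lies within the scatter).

On these data alone, how weak compound 4 really is stays open. So does whether the ring's absence or the bromine itself matters, which an amine or a methoxy group on this carbon could help separate.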